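A few compounds are considered here, and "the series" means these few. Any claim that something is new, unique, unknown or untested is made for them only; others in the source may bear on it.

Measured so far in a functional assay on MCF7 cells (Homo sapiens) for inhibition, read by resazurin assay, with a stated time of 24 h; a higher number here means a weaker inhibitor, a lower number a stronger inhibitor:
- compound 1 `O=C1Nc2c(C(F)(F)F)cccc2C1(c1ccc(O)cc1)N1CCC(F)(F)CC1`: 35 nM
- compound 2 `O=C1Nc2c(C(F)(F)F)cccc2C1(c1ccc(OC(F)(F)F)cc1)c1cc(F)c(O)c(F)c1`: > 1000 nM, a limit and not a number

Compound 2 stands at the limit of > 1000 nM in this assay, at which 1 of the 2 values shown sits. Compound 3 `Cc1cc(C2(c3ccc(OC(F)(F)F)cc3)C(=O)Nc3c(C(F)(F)F)cccc32)ccc1O` differs from it by having 4-hydroxy-3-methylphenyl in place of 3,5-difluoro-4-hydroxyphenyl on a saturated ring carbon. Among the measured compounds shown here, no measured pair shows what this swap does. Starting from the limit of compound 2 at > 1000 nM, no change beyond the scatter is expected in this assay. The estimated step, a step that the limit leaves unreadable from compound 2 to compound 3, is therefore expected to be small. For compound 3 the estimate is 1500 nM, with an expected range of 400 nM to 6000 nM.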

Compound 3, half-maximal inhibitory concentration: > 1000 nM
Compound 3 ended at the assay's limit; the forecaster's own chance of this, stated with the estimate: 60%; the middle value does not contradict the limit.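

No step can be read from compound 2 to compound 3, since each ended at a limit and not a number: the limit of > 1000 nM in this assay, at which 2 of the 3 values shown sit.

The compounds shown leave open whether 4-hydroxy-3-methylphenyl in place of 3,5-difluoro-4-hydroxyphenyl on a saturated ring carbon changes inhibition in this assay at all.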